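Working notes: methyl in place of methylsulfanyl

The source may report more compounds than this note shows. Statements on the series, on what has been measured and on what is new or still open speak of the compounds shown alone.

In an ADME assay on THP-1 cells (Homo sapiens) for cytotoxicity, read by trypan blue exclusion, with a stated time of 24 h (a higher number here means a weaker inhibitor, a lower number a stronger inhibitor), compound 1 (`N#C[Se]Cc1ccc([N+](=O)[O-])cc1`) gives 16800 nM, and compound 2 (`CSc1ccc(C[Se]C#N)cc1`) gives 17000 nM. These two values cannot be told apart: the measured step is a 1.0-fold higher number from compound 1 to compound 2 (0.01 log units; within the scatter). Compound 2 therefore stands level with compound 1 in this assay.

Compound 3 (`Cc1ccc(C[Se]C#N)cc1`) has not yet been measured. It differs from compound 2 by methyl in place of methylsulfanyl on an aromatic carbon.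

Among the compounds with values here, only one measured step bears on this change, the exchange of nitro for methylsulfanyl on an aromatic carbon, and no measured compound carries methyl. With that single step as the guide, a 1.0-fold higher number from compound 1 to compound 2 (0.01 log units; within the scatter), no shift beyond the scatter is expected and no direction is favoured. The estimated step is a 1.1-fold lower number from compound 2 to compound 3 (0.03 log units; within the scatter). Compound 3 is expected at 16000 nM, with an estimated range of 8000 nM to 32000 nM.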

Compound 3, half-maximal inhibitory concentration: 24000 nM
Estimate against measurement, compound 3: 1.5-fold (0.18 log units) below; low and high end bracket the measured number.
By their numbers in this assay, from the lowest: compounds 1, 2 and 3 (each within the scatter of the next).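

Methyl in place of methylsulfanyl gives a 1.4-fold higher number from compound 2 to compound 3 (0.15 log units; within the scatter) in this assay and methyl in place of nitro gives a 1.4-fold higher number from compound 1 to compound 3 (0.15 log units; within the scatter) in the same read-out, so all three groups on this aromatic carbon, para to a group of 4 heavy atoms, now lie within the scatter of one another. The series thus extends to a group with 0 hydrogen-bond acceptors, in place of the 1 counted for methylsulfanyl, with no step beyond the scatter in this assay for these three compounds. Nothing shown here offers an explanation for these values.

Going by these compounds, whether an amine, a carboxylic acid or a longer chain at this position would stay within the same scatter remains open. The compounds shown also leave open how the values respond to any change in the shared core away from this position.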